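The source may hold more compounds than are shown below. What is called first, only, known or untested is meant among the compounds shown, and "the series" means these compounds.

Measured so far:
compound 1 `O=C(O)CCc1ccc(OCc2nc(-c3cccc(Br)c3)no2)cc1` gives 1260 nM
compound 2 `CC(Oc1ccc(CCC(=O)O)cc1)c1nc(-c2cccs2)no1` gives 4000 nM
compound 3 `COc1cccc(-c2noc(COc3ccc(CCC(=O)O)cc3Cl)n2)c1` gives 3000 nM

All three values come from a functional assay on CHO cells for agonist activity at Free fatty acid receptor 1 (Homo sapiens), read by FLIPR and calcium flux, in the presence of a further agent that is not named here; a higher number here means that more compound is needed for the effect, a lower number that less compound is needed. Compound 1 has the lowest number of the three: compound 3 sits a moderate distance above it, and compound 2 further above it, both gaps beyond the scatter. Compound 2 differs from compound 1 in more than one place, so its value cannot be tied to any single change; the same holds for compound 3. Among the compounds with values here, no pair of measured compounds here differs in one place only, so no single step is available to lean on.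

The next compound to be measured in this assay is compound 4 `O=C(O)CCc1ccc(OCc2nc(-c3ccco3)no2)cc1`. Relative to compound 1 the change is furan-2-yl in place of 3-bromophenyl on an aromatic carbon. The core and the acid-bearing portion are unchanged.

With no measured step of this kind in the set, the expectation rests on compound 1 and on the change itself. The expected step of a 2.4-fold higher number from compound 1 to compound 4 (0.38 log units; beyond the scatter) is toward a higher number, beyond the scatter but not large. Compound 4 is thus estimated at 3000 nM, with a range from 1000 nM to 9000 nM, which keeps compound 1 as the lowest number in the set.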

Compound 4, half-maximal effective concentration: > 100000 nM
Compound 4 ended at the assay's limit (the forecaster's own chance of this, stated with the estimate: 10%); middle value at least 33-fold (1.52 log units) from the limit.
By their numbers in this assay, from the lowest: compound 1; then compounds 3 and 2 (each within the scatter of the next). At a limit, above all of these: compound 4.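

Compound 4 reads > 100000 nM in this assay, which is a limit of the assay and not a number. This gives the set its first step in one place: furan-2-yl in place of 3-bromophenyl, on the aromatic carbon between two ring nitrogen atoms, produces an at least 79-fold higher number from compound 1 to compound 4 (1.89 log units; beyond the scatter), a large step with the core and the acid-bearing portion unchanged, so this carbon is not indifferent to the aromatic group it carries. Going by these compounds, the true size of the step stays unknown, and only a lower bound can be read, as one value shown sits at the limit: the limit of > 100000 nM in this assay, at which 1 of the 4 values shown sits.

The single step changes several things at once, as the group going from 3-bromophenyl to furan-2-yl loses the bromine, goes from a six-membered to a five-membered ring, and gains a ring oxygen, and the compounds shown do not separate these. Unsubstituted phenyl or 3-chlorophenyl on the same carbon would help show which of these differences carries the step, and whether any of the effect belongs to the bromine itself.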